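From bromo to hydroxy in a series at its limit

A few compounds are considered here, and "the series" means these few. Any claim that something is new, unique, unknown or untested is made for them only; others in the source may bear on it.

Among the compounds with values here, in a functional assay on K562 cells (Homo sapiens) for cytotoxicity, read by MTT assay, with a stated time of 5 days (on this read-out lower numbers stand for stronger inhibition and higher numbers for weaker inhibition), no compound has yet given a readable number. Compound 1 `COc1ccc(Cn2cc(-c3cc(OC)c(OC)c(OC)c3)nn2)cc1Br` reads > 10000 nM, which is a limit of the assay. Compound 2 `COc1ccc(-c2cn(Cc3cc(OC)c(OC)c(OC)c3)nn2)cc1` reads > 10000 nM, again a limit. Compound 3 `COc1ccc(-c2cn(Cc3cc(OC)c(OC)c(OC)c3)nn2)cc1Br` reads > 10000 nM, also a limit. Within the data shown here, it therefore stands with the other two, and the series so far comes down to the limit of > 10000 nM in this assay, at which 3 of the 3 values shown sit.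

Compound 4 `COc1ccc(-c2cn(Cc3cc(OC)c(OC)c(OC)c3)nn2)cc1O` differs from compound 3 by hydroxy in place of bromo on an aromatic carbon, ortho to a methoxy group: hydroxy in place of bromo on an aromatic carbon. Among the measured compounds shown here, the only measured step bearing on this carbon is a step that the two limits leave unreadable from compound 2 to compound 3. For the measured compounds named here, it offers no size to carry over, and no measured compound here carries the hydroxy group. The data therefore point to no clear gain, although a first readable number remains possible. The expected change is small and uncertain, estimated as a number no higher from compound 3 to compound 4 (the limit leaves the size open). Compound 4 is expected near 10000 nM, with an estimated range from 1500 nM to 30000 nM.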

Compound 4, half-maximal inhibitory concentration: > 10000 nM
Compound 4 was reported as a limit (the forecaster's own chance of this, stated with the estimate: 70%); the middle value lies on the limit itself.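

Compound 4 is also a limit, not a number, so the steps to it from compound 2 and compound 3 cannot be read, and the series stays where it was: the limit of > 10000 nM in this assay, at which 4 of the 4 values shown sit.

The compounds shown leave open whether hydrogen, bromo or hydroxy on this aromatic carbon makes any difference.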